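Methoxy to hydroxy: from compound 2 to compound 4

The source may hold more compounds than are shown below. What is called first, only, known or untested is meant among the compounds shown, and "the series" means these compounds.

Measured in a functional assay on MDA-MB-231 cells (Homo sapiens) for cytotoxicity, read by sulforhodamine B assay, with a stated time of 48 h, tested at 0.001 uM; a higher number here means a weaker effect of the compound at the concentration tested, a lower number a stronger effect:
compound 1 `COc1cc(C)cc(-c2c(-c3ccnc(-c4ccc(N(C)C)cc4)c3)cnn2CC#N)c1` gives 101%
compound 2 `COc1cc(C)cc(-c2nn(CC#N)cc2-c2ccnc(-c3ccc(N(C)C)cc3)c2)c1` gives 97%
compound 3 `COc1cc(C)cc(-c2nn(CC#N)cc2-c2ccc(-c3cccc(C(C)=O)c3)nc2)c1` gives 102%

Compound 2 holds the lowest of the three numbers, but its nearest neighbour is compound 1, whose number is higher by an amount within the scatter, and the furthest is compound 3, also within the scatter. No order among the three can be read from this; all three numbers sit where this assay reports a weak effect at the concentration tested.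

Compound 4 `Cc1cc(O)cc(-c2nn(CC#N)cc2-c2ccnc(-c3ccc(N(C)C)cc3)c2)c1` is the next member. It differs from compound 2 in one place: hydrogen in place of methyl on an oxygen on an aromatic ring. Put one bond further out, methoxy becomes hydroxy, and 3-methoxy-5-methylphenyl becomes 3-hydroxy-5-methylphenyl. The rest of the structure is the same as in compound 2.

Going by the values given here, no pair of measured compounds differs in a single place, so no measured step is available to guide the size of this change. Given that every number so far sits in the same narrow band, the expectation for the step from compound 2 to compound 4 in this assay is none beyond the scatter, that is, an expected step of a number 1 percentage points higher from compound 2 to compound 4 (within the scatter).

For compound 4 the estimate in this assay is 98%, with an expected range from 88% to 108%.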

Compound 4, a percentage reported as activity, at one concentration (the size of the read-out at that concentration, not a potency): 99%
Beside the measured number, compound 4's estimate is 1 percentage points below it, within the range that was stated.
By their numbers in this assay, from the lowest: compounds 2, 4, 1 and 3 (each within the scatter of the next).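

In this assay, going by these compounds alone, hydrogen in place of methyl on an oxygen on an aromatic ring gives a number 2 percentage points higher from compound 2 to compound 4 (within the scatter) and so provides the first single-place step: going from methoxy to hydroxy, from 3-methoxy-5-methylphenyl to 3-hydroxy-5-methylphenyl, leaves the read-out unchanged within the scatter. Both compounds sit where the read-out reports a weak effect at the one concentration tested, so this step cannot separate a position that tolerates the change from a series showing little effect at that concentration. Within the data shown here, no measurement accompanying this step bears on the result.

From the compounds shown here alone, whether a longer chain on the same oxygen, such as ethoxy or benzyloxy, or an amine in place of the methoxy or hydroxy group, would move the number remains open. Also open, going by these compounds, is whether compound 2 and compound 4 would stay together at higher concentrations, where a stronger or weaker effect could show a difference that this single-concentration read-out cannot.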